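Notes on a sulfonamide series: methyl in place of bromo

This account rests on a few compounds, and the source may have more. Where it says the series, first, only, none or still open, it means among the compounds named here.

Compound 1 `O=S(=O)(NCCNc1nccc(-c2c(-c3cccc(F)c3)nc3sccn23)n1)c1ccc(Br)cc1` is measured in a functional assay on A-375 cells (Homo sapiens) for cytotoxicity, read by MTT assay (a higher number here means a weaker inhibitor, a lower number a stronger inhibitor), where compound 1 gives 13500 nM. Among the three measured compounds it stands second highest. Its nearest neighbour is compound 2 `O=S(=O)(NCCNc1nccc(-c2c(-c3cccc(F)c3)nc3sccn23)n1)c1ccc(Cl)cc1`, which in this assay gives 18600 nM; the step of a 1.4-fold higher number from compound 1 to compound 2 (0.14 log units; within the scatter) is within the scatter. The furthest is compound 3 `O=S(=O)(NCCCNc1nccc(-c2c(-c3cccc(F)c3)nc3sccn23)n1)c1ccc(Cl)cc1`, which in this assay gives 5900 nM; the step of a 2.3-fold lower number from compound 1 to compound 3 (0.36 log units; beyond the scatter) is modest, as is a 3.2-fold lower number from compound 2 to compound 3 (0.50 log units; beyond the scatter).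

Compound 4 `Cc1ccc(S(=O)(=O)NCCNc2nccc(-c3c(-c4cccc(F)c4)nc4sccn34)n2)cc1` differs from compound 1 by methyl in place of bromo on an aromatic carbon. For the measured compounds named here, only one measured step bears on a change at this aromatic carbon: a 1.4-fold higher number from compound 1 to compound 2 (0.14 log units; within the scatter), which exchanged one halogen for another and stayed within the scatter. The other two steps, a 2.3-fold lower number from compound 1 to compound 3 (0.36 log units; beyond the scatter) and a 3.2-fold lower number from compound 2 to compound 3 (0.50 log units; beyond the scatter), alter the chain instead and do not bear on this exchange. Going by the values given here, no measured compound carries a methyl at this place, so the direction of the step cannot be read from the series; the one neighbouring exchange suggests little movement either way.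

Compound 4 is therefore expected to give about 16000 nM in this assay, within 6000 nM to 40000 nM, a step of a 1.2-fold higher number from compound 1 to compound 4 (0.07 log units; within the scatter) that is expected to remain within the scatter.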

Compound 4, half-maximal inhibitory concentration: 15400 nM
Beside the measured number, compound 4's estimate is 1.0-fold (0.02 log units) above it, and the stated range covers the measured number.
By their numbers in this assay, from the lowest: compound 3; then compounds 1, 4 and 2 (each within the scatter of the next).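

In this assay, methyl in place of a halogen on this aromatic carbon leaves the number within the scatter, both against bromo (a 1.1-fold higher number from compound 1 to compound 4 (0.06 log units; within the scatter)) and against chloro (a 1.2-fold lower number from compound 2 to compound 4 (0.08 log units; within the scatter)), so compounds 1, 2 and 4 are not told apart. The earlier compounds shown here showed this only for one halogen exchanged for another; the series now shows it also for a carbon group of the same heavy-atom count, with no hydrogen-bond donors or acceptors on either side of the change. The step (a 2.6-fold higher number from compound 3 to compound 4 (0.42 log units; beyond the scatter)) lies beyond the scatter but changes the chain and the aromatic substituent together, so it cannot be assigned to this position, and no available evidence accounts for the flat response at this aromatic carbon.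

Still open, on these data alone, is whether an amine, a carboxylic acid or a larger group such as phenyl on this aromatic carbon would move the number beyond the scatter. Also open, as far as these compounds go, is whether 4-methylphenyl or 4-bromophenyl on the chain of compound 3 would behave as they do on the chain of compound 1.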